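Aryl Variation on a Fused Core in Ehrlich Cells

This account rests on a few compounds, and the source may have more. Where it says the series, first, only, none or still open, it means among the compounds named here.

compound 1 `COc1cc(N2C(N)=C(C#N)C(c3ccc([N+](=O)[O-])cc3)C3=C2CC(C)(C)CC3=O)cc(OC)c1OC`: 70%
compound 2 `COc1cc(N2C(N)=C(C#N)C(c3ccc(Cl)cc3Cl)C3=C2CC(C)(C)CC3=O)cc(OC)c1OC`: 95%

In a functional assay on Ehrlich cells (Mus musculus) for cytotoxicity, tested at 50 ug/mL (a higher number here means a stronger effect of the compound at the concentration tested, a lower number a weaker effect), compound 1 gives 70% and compound 2 gives 95%, the higher of the two numbers. For the measured compounds named here, the only measured step, a number 25 percentage points higher from compound 1 to compound 2 (beyond the scatter), shows that the group on the saturated ring carbon can move the read-out by a modest amount. Compound 3 `COc1ccccc1C1C(C#N)=C(N)N(c2cc(OC)c(OC)c(OC)c2)C2=C1C(=O)CC(C)(C)C2` alters that same group: 2-methoxyphenyl in place of 2,4-dichlorophenyl on a saturated ring carbon. Going by the values given here, no measured step covers this particular exchange, so the expectation rests only on the size of the one step seen. Compound 3 is expected to give 70%, within 45% to 92%. The step of a number 25 percentage points lower from compound 2 to compound 3 (beyond the scatter) is therefore expected to be a modest fall.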

Compound 3, a percentage reported as activity, at one concentration (the size of the read-out at that concentration, not a potency): 70%
The estimate for compound 3 equals the measured number at the digits printed; measured number inside the range.
By their numbers in this assay, from the lowest: compounds 1 and 3 (each within the scatter of the next); then compound 2.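

In this assay the step of a number 25 percentage points lower from compound 2 to compound 3 (beyond the scatter) shows that the higher read-out of the 2,4-dichlorophenyl compound is not shared by 2-methoxyphenyl at this saturated ring carbon. The step of no change at the digits printed from compound 1 to compound 3 (within the scatter) places 2-methoxyphenyl level with 4-nitrophenyl, so among these three groups only 2,4-dichlorophenyl stands apart. Nothing available here explains this result. On these data alone, it remains open whether a single chlorine on the phenyl ring would keep the higher read-out, and how a phenyl ring bearing an amine or a carboxylic acid would behave at this position.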